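The compounds below may be only part of what the source reports. "The series", "measured", "known", "first", "only" and "open" are said of these compounds alone.

In a functional assay on MT4 cells (Homo sapiens) for cytotoxicity, read by MTT assay, with a stated time of 5 days (a lower number here means that less compound is tolerated, a higher number that more compound is tolerated), compound 1, `N#Cc1ccc(Nc2nccc(Oc3ccc(-c4ccc(C#N)cc4)c(F)c3)n2)cc1`, gives > 307000 nM, which is a limit of the assay rather than a measured number. Compound 2, `N#Cc1ccc(Nc2nccc(Oc3ccc(-c4ccc(C#N)cc4)c(C(F)(F)F)c3)n2)cc1`, gives in this assay > 273000 nM, again a limit and not a number. Where compound 2 stands can therefore only be bounded: its own value is a limit, and the one further value shown is a limit as well, so the step that the two limits leave unreadable from compound 1 to compound 2 cannot be read in size or in direction. The unmeasured compound 3, `COc1cc(Oc2ccnc(Nc3ccc(C#N)cc3)n2)ccc1-c1ccc(C#N)cc1`, differs from compound 2 by methoxy in place of trifluoromethyl on an aromatic carbon. Going by the values given here, the only measured step, that from compound 1 to compound 2, bears on this change solely in that both of its ends sit at limits, the limit of > 273000 nM in this assay, at which 1 of the 2 values shown sits, and (the limit of > 307000 nM in this assay, at which 1 of the 2 values shown sits), so no step beyond the scatter can be inferred from it in either direction. Compound 3 is therefore expected to remain close to its parent in this assay, with the expected step being an at least 1.0-fold lower number from compound 2 to compound 3 (0.03 log units; that floor lies within the scatter). The estimate for compound 3 in this assay is 250000 nM, within the range from 100000 nM to 400000 nM.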

Compound 3, half-maximal cytotoxic concentration: > 298000 nM
Compound 3: only a limit was reported (the forecaster's own chance of this, stated with the estimate: 70%); at least 1.1-fold (0.07 log units) between middle value and limit.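

In this assay compound 3 gives > 298000 nM, which is a limit of the assay and not a number. Going by these compounds alone, with compound 1, compound 2 and compound 3 all at limits, no step among them can be read. The compounds shown leave open where their true values lie, and whether fluoro, trifluoromethyl and methoxy differ at all here.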